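The compounds below may be only part of what the source reports. "The series", "measured", "known", "first", "only" and "open" are said of these compounds alone.

Measured in a physicochemical assay for lipophilicity; on this read-out lower numbers stand for lower lipophilicity and higher numbers for higher lipophilicity:
compound 1 `COC(C)(C)CCCC(C)C/C=C/C(C)=C/C(=O)OCCC(C)C` — 7.03
compound 2 `CCSC(=O)/C=C(C)/C=C/CC(C)CCCC(C)(C)OC` — 6.78
compound 3 `C#CCSC(=O)/C=C(C)/C=C/CC(C)CCCC(C)(C)OC` — 5.9

Compound 3 stands lowest of the three numbers in this assay; compound 2 is nearest, a number 0.88 log units lower from compound 2 to compound 3 (beyond the scatter), and compound 1 furthest, a number 1.13 log units lower from compound 1 to compound 3 (beyond the scatter). Compound 4 `CCC(C)C(=O)/C=C(C)/C=C/CC(C)CCCC(C)(C)OC` is not yet measured. The change from compound 3 to compound 4: sec-butyl in place of propargylsulfanyl on a carbonyl carbon. For the measured compounds named here, two measured steps bear on it. The ethynyl for methyl step, a number 0.88 log units lower from compound 2 to compound 3 (beyond the scatter), is undone here, since the triple bond leaves; the propargylsulfanyl itself entered with a number 1.13 log units lower from compound 1 to compound 3 (beyond the scatter). Both point upward, so a modest rise beyond the scatter is expected, roughly back to the region of compound 1 and compound 2, whose values are within the scatter of each other. Compound 4 is therefore estimated at 6.9, range 6.3 to 7.5, a step of a number 1.00 log units higher from compound 3 to compound 4 (beyond the scatter).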

Compound 4, partition coefficient: 6.02
The estimate for compound 4 lay 0.88 log units above the measured number, outside the stated range (below it).
By their numbers in this assay, from the lowest: compounds 3 and 4 (each within the scatter of the next); then compounds 2 and 1 (each within the scatter of the next).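

In this assay, sec-butyl on the carbonyl carbon reads level with propargylsulfanyl (a number 0.12 log units higher from compound 3 to compound 4 (within the scatter)), so the low number of compound 3 does not require the triple bond or the sulfur. Sec-butyl does not track the other two groups at this place (a number 0.76 log units lower from compound 2 to compound 4 (beyond the scatter); a number 1.01 log units lower from compound 1 to compound 4 (beyond the scatter)), and the size of the group leaving does not settle the reading. No measurement here accounts for these differences.

Still open, going by these compounds, is how an amine or a methoxy group on the carbonyl carbon would read in this assay. An unbranched butyl would show whether the branching of sec-butyl matters.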